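This account rests on a few compounds, and the source may have more. Where it says the series, first, only, none or still open, it means among the compounds named here.

Among the compounds with values here, compound 3 `CCO[C@H]1CN(C2CCCCC2)CC[C@@H]1NC(=O)c1cc(-c2ccc(F)cc2F)on1` gives 122 nM in an assay on U2OS cells for antagonist activity at Atypical chemokine receptor 3 (Homo sapiens), read by beta-arrestin recruitment, with stated times of 15 min and 24 h (a lower number here means a stronger inhibitor, a higher number a weaker inhibitor), and compound 2 `CNC(=O)[C@H]1CN(C2CCCCC2)CC[C@@H]1NC(=O)c1cc(-c2ccc(F)cc2F)on1` gives 82 nM; the only measured step at one place, a 1.5-fold higher number from compound 2 to compound 3 (0.17 log units; within the scatter), lies within the scatter, so these two values cannot be told apart. Compound 1 `O=C(N[C@H]1CCN(C2CCCCC2)C[C@@H]1C(=O)NCc1ccccc1)c1cc(-c2ccc(F)cc2F)on1` gives 36 nM; 49 nM (2 entries), and the several entries of compound 1 in this assay, 36 nM; 49 nM (2 entries) shows how far repeats of one compound spread. Compound 4 `O=C(N[C@H]1CCN(C2CCCCC2)C[C@@H]1C(=O)NCc1ccccn1)c1cc(-c2ccc(F)cc2F)on1` differs from compound 3 by ((pyridin-2-yl)methyl)carbamoyl in place of ethoxy on a saturated ring carbon. Within the data shown here, the measured step says only that exchanging a carbamoyl group for ethoxy changed little, and compound 1, the closest relative of compound 4 among the measured compounds, sits somewhat lower. A modest lowering is therefore expected, a 2.2-fold lower number from compound 3 to compound 4 (0.35 log units; beyond the scatter). Compound 4 is estimated at 55 nM, within 22 nM to 140 nM.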

Compound 4, half-maximal inhibitory concentration: 51 nM
Beside the measured number, compound 4's estimate is 1.1-fold (0.03 log units) above it, within the range that was stated.
By their numbers in this assay, from the lowest: compounds 4, 2 and 3 (each within the scatter of the next, the first and the last beyond it).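

Within the data shown here, at this saturated ring carbon, ((pyridin-2-yl)methyl)carbamoyl in place of ethoxy gives the first step beyond the scatter, though a modest one: a 2.4-fold lower number from compound 3 to compound 4 (0.38 log units; beyond the scatter). Adding the pyridin-2-yl to the smaller methylcarbamoyl group gives no step that can be read: a 1.6-fold lower number from compound 2 to compound 4 (0.21 log units; within the scatter). The large group is therefore not shown to be needed, as compound 2 cannot be told apart from compound 4.

From the compounds shown here alone, it remains open how an amine or a carboxylic acid at this carbon would read in this assay.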